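A few compounds are considered here, and "the series" means these few. Any claim that something is new, unique, unknown or untested is made for them only; others in the source may bear on it.

Measured so far in a functional assay on MDA-MB-231 cells (Homo sapiens) for cytotoxicity, read by MTT assay, with a stated time of 72 h; on this read-out higher numbers stand for weaker inhibition and lower numbers for stronger inhibition:
- compound 1 `O=C(CN1CCN(c2nnc(Cc3ccccc3)c3ccccc23)CC1)Nc1c(F)cccc1F`: 5490 nM
- compound 2 `Cc1ccc(NC(=O)CN2CCN(c3nnc(Cc4ccncc4)c4ccccc34)CC2)c(C)c1`: 240 nM
- compound 3 `Cc1cccc(Cl)c1NC(=O)CN1CCN(c2nnc(Cc3ccccc3)c3ccccc23)CC1`: 3920 nM

Compound 2, at 240 nM, gives the lowest number of the three. The gap is beyond the usual scatter, both to compound 3 at 3920 nM and to compound 1 at 5490 nM. However, compound 2 differs from these two in more than one place, so their values cannot show what its amide group alone contributes.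

Compound 4 `O=C(CN1CCN(c2nnc(Cc3ccncc3)c3ccccc23)CC1)Nc1ccc(F)c(Cl)c1` differs from compound 2 in one place: 3-chloro-4-fluorophenyl in place of 2,4-dimethylphenyl on an amide-type nitrogen. Within the data shown here, only one measured step involves a change at this place: a 1.4-fold lower number from compound 1 to compound 3 (0.15 log units; within the scatter). That step stayed within the scatter, which gives a modest hint that swapping this group need not move the number much. It is thin evidence, since it rests on a single pair with different groups and a different remainder of the molecule. No direction can be drawn from it, so no step beyond the scatter is expected.

The estimated change is a 1.3-fold higher number from compound 2 to compound 4 (0.10 log units; within the scatter). In this assay the expected value for compound 4 is 300 nM, with an estimated range of 90 nM to 1200 nM.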

Compound 4, half-maximal inhibitory concentration: 4 nM
Compound 4: middle estimate off by 75-fold (1.88 log units), on the high side; the whole stated range lies above it.
By their numbers in this assay, from the lowest: compound 4; then compound 2; then compounds 3 and 1 (each within the scatter of the next).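

In this assay, the group on the amide-type nitrogen proves able to move the number strongly: with the rest of the molecule unchanged, 3-chloro-4-fluorophenyl in place of 2,4-dimethylphenyl gives a 60-fold lower number from compound 2 to compound 4 (1.78 log units; beyond the scatter). Among these compounds, the only earlier step at this place, a 1.4-fold lower number from compound 1 to compound 3 (0.15 log units; within the scatter), stayed within the scatter, though it involved different groups on a different remainder of the molecule, so this place can respond little to one swap and sharply to another. The two groups in the new step have the same count of heavy atoms and the same carbon-only aromatic ring, and nothing available explains the size of the step.

This single swap removes both methyl groups and adds a chlorine and a fluorine at once, so the compounds shown cannot say which of these changes carries the drop, and a plain phenyl, or a phenyl bearing only the chlorine or only the fluorine, would be needed to separate them. Going by these compounds, it also remains open whether 3-chloro-4-fluorophenyl would give a similar step on the core of compound 1.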